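The source may report more compounds than this note shows. Statements on the series, on what has been measured and on what is new or still open speak of the compounds shown alone.

Of the compounds shown here, two built around related cores have been tested in a functional assay on T47D cells (Homo sapiens) for inhibition, read by sulforhodamine B assay, with a stated time of 48 h; on this read-out higher numbers stand for weaker inhibition of growth and lower numbers for stronger inhibition of growth. There, compound 1 `Cc1nnc(-c2nn(-c3ccccc3)c(-c3ccccc3)c2C#N)c2cn(-c3ccccc3)nc12` gives 9140 nM. Compound 2 `N#Cc1c(-c2nnc(-c3nn(-c4ccccc4)c(-c4ccccc4)c3C#N)c3nn(-c4ccccc4)cc23)nn(-c2ccccc2)c1-c1ccccc1` gives 81000 nM, the higher of the two numbers, and the gap between them lies beyond the usual scatter of repeated measurements. Compound 2 therefore stands at the weak end of this small set, and its number is the only direct reference for what follows.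

Compound 3 `N#Cc1c(-c2nnc(-c3nn(-c4ccccc4)c(-c4ccccc4)c3C#N)c3nn(-c4ccc(Cl)cc4)cc23)nn(-c2ccccc2)c1-c1ccccc1` departs from compound 2 in a single place, chloro in place of hydrogen on an aromatic carbon, turning a phenyl into a 4-chlorophenyl, para to a large group. For the measured compounds named here, no measured pair shows what such a change does, so the expectation rests on the value of compound 2 alone. In this assay no shift beyond the scatter is expected, and the estimated change is a 1.2-fold lower number from compound 2 to compound 3 (0.10 log units; within the scatter). For compound 3 the estimated value is 65000 nM, with an expected range from 22000 nM to 170000 nM.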

Compound 3, concentration for 50% growth inhibition: 16000 nM
Beside the measured number, compound 3's estimate is 4.1-fold (0.61 log units) above it; measured number outside the range, below it.
By their numbers in this assay, from the lowest: compounds 1 and 3 (each within the scatter of the next); then compound 2.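

In this assay, turning a phenyl into a 4-chlorophenyl, para to a large group, gives a 5.1-fold lower number from compound 2 to compound 3 (0.70 log units; beyond the scatter), so this position on compound 2 responds to substitution and is not a silent spot on the molecule. For the compounds shown here, this is the first measured pair to show what chloro in place of hydrogen on an aromatic carbon does, and it moves the number towards stronger inhibition of growth, although it remains a single pair and sets no general rule. Nothing among the data shown explains why this one chlorine has this effect.

The compounds shown leave open whether fluoro, methoxy or an amine at the same place would shift the number in the same direction, and whether a bromo would go further than chloro. They also leave open whether chloro placed on one of the other phenyl groups, or the same change made on compound 1, would give a step of similar size.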